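Lengthening the Amide Chain on a Shared Core

This account rests on a few compounds, and the source may have more. Where it says the series, first, only, none or still open, it means among the compounds named here.

Of the compounds shown here, two with a shared core have numbers so far. In a functional assay on A549 cells (Homo sapiens) for antiproliferative activity, read by CCK-8 assay, with a stated time of 72 h (on this read-out higher numbers stand for weaker inhibition of growth and lower numbers for stronger inhibition of growth), compound 1 `CCC1C(=O)N(C)c2cnc(Nc3ccc(S(=O)(=O)NCC(C)C)cc3)nc2N1c1ccn(C)n1` gives 31600 nM, and compound 2 `CCC1C(=O)N(C)c2cnc(-n3ccc4cc(C(=O)NC)ccc43)nc2N1c1ccn(C)n1` gives 43100 nM. These values lie within the usual scatter of each other, so compound 2 cannot be ranked against compound 1.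

Compound 3 `CCC1C(=O)N(C)c2cnc(-n3ccc4cc(C(=O)NCC(C)C)ccc43)nc2N1c1ccn(C)n1` differs from compound 2 in one place: isopropyl in place of hydrogen on a saturated chain carbon bound to an amide-type nitrogen. Here isopropyl stands in place of hydrogen on a saturated chain carbon bound to an amide-type nitrogen, so methylcarbamoyl becomes isobutylcarbamoyl. Among the compounds with values here, no measured pair shows this change on its own, which leaves the expectation loosely grounded. In this assay, the expected change is small, a 1.5-fold lower number from compound 2 to compound 3 (0.19 log units; within the scatter), toward stronger inhibition of growth, and it may not exceed the scatter. For compound 3 the estimated value is 28000 nM, with an expected range of 9000 nM to 70000 nM.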

Compound 3, concentration for 50% growth inhibition: 19200 nM
Compound 3: the middle estimate sits 1.5-fold (0.16 log units) above what was measured; measured number inside the range.
By their numbers in this assay, from the lowest: compounds 3, 1 and 2 (each within the scatter of the next, the first and the last beyond it).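

Within the data shown here, compound 2 and compound 3 give the first reading of a single change on the shared core: going from methylcarbamoyl to isobutylcarbamoyl brings a 2.2-fold lower number from compound 2 to compound 3 (0.35 log units; beyond the scatter) in this assay toward stronger inhibition of growth. This place, on a saturated chain carbon bound to an amide-type nitrogen, therefore responds to the isopropyl group, although the step is modest and compound 3 still gives 19200 nM. Nothing in the data at hand explains this shift.

One pair cannot show whether the trend continues with a longer chain such as n-hexyl or reverses with a tert-butyl group at this place. It also leaves open how an amine or a carboxylic acid there would change the number.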